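Swapping 3-fluorophenyl for 1,3-thiazol-2-yl on the amide-type nitrogen

This account rests on a few compounds, and the source may have more. Where it says the series, first, only, none or still open, it means among the compounds named here.

Of the compounds shown here, three sharing one core have been measured in a functional assay on HepG2 cells (Homo sapiens) for inhibition, read by MTT assay, with a stated time of 72 h; a higher number here means a weaker inhibitor, a lower number a stronger inhibitor. Compound 1 `CCc1ccc(NC(=O)C2CCN(C/C=C/c3ccccc3)CC2)cc1` gives 23300 nM. Compound 2 `CCCc1ccc(NC(=O)C2CCN(C/C=C/c3ccccc3)CC2)cc1` gives 9410 nM. Compound 3 `O=C(Nc1cccc(F)c1)C1CCN(C/C=C/c2ccccc2)CC1` gives 51100 nM, the highest number of the three, which makes it the weakest inhibitor of this small set.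

The next compound is compound 4 `O=C(Nc1nccs1)C1CCN(C/C=C/c2ccccc2)CC1`, and the change is 1,3-thiazol-2-yl in place of 3-fluorophenyl on an amide-type nitrogen. In words, this is 1,3-thiazol-2-yl in place of 3-fluorophenyl on an amide-type nitrogen.

Two measured steps alter the group on that nitrogen: a 2.2-fold higher number from compound 1 to compound 3 (0.34 log units; beyond the scatter) and a 5.4-fold higher number from compound 2 to compound 3 (0.73 log units; beyond the scatter). Both are modest, although beyond the scatter. The step of a 2.5-fold lower number from compound 1 to compound 2 (0.39 log units; beyond the scatter) concerns only the saturated chain and bears on the change less directly. For the measured compounds named here, no measured compound has a five-membered aromatic ring on that nitrogen, so the data support neither direction.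

In this assay, no step beyond the scatter is therefore expected, although the modest steps seen so far leave room on either side. The estimated step is a 1.3-fold lower number from compound 3 to compound 4 (0.11 log units; within the scatter). Compound 4 is expected at 40000 nM, with an estimated range from 15000 nM to 100000 nM.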

Compound 4, half-maximal inhibitory concentration: 22400 nM
Compound 4: middle estimate off by 1.8-fold (0.25 log units), on the high side; the measured number falls inside the stated range.
By their numbers in this assay, from the lowest: compound 2; then compounds 4 and 1 (each within the scatter of the next); then compound 3.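

Working notes on the group on the amide-type nitrogen: in this assay, a five-membered aromatic ring with 2 hetero atoms is tolerated on this nitrogen, and 1,3-thiazol-2-yl in place of 3-fluorophenyl gives a step beyond the scatter (a 2.3-fold lower number from compound 3 to compound 4 (0.36 log units; beyond the scatter)). Set against the alkyl-substituted phenyl groups, 1,3-thiazol-2-yl cannot be told apart from 4-ethylphenyl (a 1.0-fold lower number from compound 1 to compound 4 (0.02 log units; within the scatter)), yet it does not match 4-propylphenyl (a 2.4-fold higher number from compound 2 to compound 4 (0.38 log units; beyond the scatter)), so the group on compound 2 still gives the lowest number of the four, beyond the scatter of each of the others. No measurement of any property of these groups bears on the result, so these steps stand as observations only.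

Still open, as far as these compounds go, is whether a propyl chain on the 1,3-thiazol-2-yl ring would lower the number as the longer chain did on the phenyl ring of compound 2. Also open, from the compounds shown here alone, is how 1,3-oxazol-2-yl or pyridin-2-yl on the same nitrogen would compare with 1,3-thiazol-2-yl, which would show whether the sulfur-containing ring itself matters here.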